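From phenyl to 3,4,5-trimethoxyphenyl in compound 4

The compounds below may be only part of what the source reports. "The series", "measured", "known", "first", "only" and "open" are said of these compounds alone.

- compound 1 `COc1cc(/C=C/C(=O)/C=C/c2cccc3ccccc23)ccc1OCc1cn(CCOc2cc(=O)oc3ccccc23)nn1` gives 89%
- compound 2 `COc1cc(/C=C/C(=O)/C=C/c2ccccc2)ccc1OCc1cn(CCCCOc2cc(=O)oc3ccccc23)nn1` gives 36%
- compound 3 `COc1ccc(/C=C/C(=O)/C=C/c2ccc(OCc3cn(CCOc4cc(=O)oc5ccccc45)nn3)c(OC)c2)cc1OC` gives 90%

These numbers come from a functional assay on THP-1 cells (Homo sapiens) for inhibition, read by sulforhodamine B assay, with a stated time of 48 h, tested at 50 uM (a higher number here means more inhibition of growth at the concentration tested, a lower number less inhibition of growth), and compound 2 has the lowest of the three. Its gap to each of the other two compounds lies beyond the usual scatter.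

The unmeasured compound 4 `COc1cc(/C=C/C(=O)/C=C/c2cc(OC)c(OC)c(OC)c2)ccc1OCc1cn(CCCCOc2cc(=O)oc3ccccc23)nn1` departs from compound 2 in one place, on a double-bonded chain carbon bound to a double-bonded chain carbon, and the change is 3,4,5-trimethoxyphenyl in place of phenyl on a double-bonded chain carbon bound to a double-bonded chain carbon with 3,4,5-trimethoxyphenyl in place of phenyl.

Among the compounds with values here, only one measured step touches this place. It is a number 1 percentage points higher from compound 1 to compound 3 (within the scatter) and it argues for little movement when one group there replaces another. Within the data shown here, no measured pair isolates phenyl at this place, so the low number of compound 2 remains unexplained. Compound 3 carries 3,4-dimethoxyphenyl there and gives 90% which leaves room for some rise, although compound 1 without any methoxy group stands level with it.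

A moderate upward move is therefore expected, and the estimated move is a number 14 percentage points higher from compound 2 to compound 4 (beyond the scatter) in this assay with wide uncertainty. The estimate for compound 4 is 50% with an expected range from 30% to 78% on this read-out.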

Compound 4, percent growth inhibition at one concentration: 65%
For compound 4 the middle estimate is 15 percentage points below the measured one, and the stated range covers the measured number.
By their numbers in this assay, from the lowest: compound 2; then compound 4; then compounds 1 and 3 (each within the scatter of the next).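

Putting 3,4,5-trimethoxyphenyl in place of phenyl, on a double-bonded chain carbon bound to a double-bonded chain carbon, gives a number 29 percentage points higher from compound 2 to compound 4 (beyond the scatter) in this assay. Within the data shown here, this position is therefore not indifferent to what sits on it, something the only earlier step here, a number 1 percentage points higher from compound 1 to compound 3 (within the scatter), could not show; that flat step also swapped a different pair of groups and sits on a different chain, so it does not set a general rule for this place. Nothing measured here explains why the three methoxy groups go with the higher number, and no supporting data on the cause are available.

The compounds shown leave open whether a single methoxy group, or an amine or a carboxylic acid on the phenyl ring, would give a similar rise at this place. They also leave open how much the chain itself contributes to the numbers, and no pair shown here differs in that chain alone.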